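The compounds below may be only part of what the source reports. "The series", "measured", "known", "first", "only" and "open" are said of these compounds alone.

Measured so far:

compound 1 `Cc1ncc([N+](=O)[O-])n1CCCBr` — 54.8 ug/mL
compound 2 `Cc1ncc([N+](=O)[O-])n1CCCN1CCCCC1` — a limit, > 100 ug/mL
compound 3 `Cc1ncc([N+](=O)[O-])n1CCCN1CCCC1` — a limit, > 100 ug/mL

In an ADME assay on J774 cells (Mus musculus) for cytotoxicity, read by resazurin assay, with a stated time of 24 h (a higher number here means a weaker inhibitor, a lower number a stronger inhibitor), compound 1 gives 54.8 ug/mL. For compound 2 the assay returns only a limit, > 100 ug/mL. For compound 3 the assay likewise returns only a limit, > 100 ug/mL. Compound 3 therefore stands without a number of its own; it sits where the limit of > 100 ug/mL in this assay, at which 2 of the 3 values shown sit, places it, together with compound 2. The readable steps are an at least 1.8-fold higher number from compound 1 to compound 2 (0.26 log units; that floor lies within the scatter) and an at least 1.8-fold higher number from compound 1 to compound 3 (0.26 log units; that floor lies within the scatter), both floors that lie within the scatter. The step that the two limits leave unreadable from compound 2 to compound 3 cannot be read, since both ends are limits.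

Compound 4 `Cc1ncc([N+](=O)[O-])n1CCCCN1CCCC1` is the next member. Relative to compound 3 the change is (pyrrolidin-1-yl)methyl in place of pyrrolidin-1-yl on a saturated chain carbon, three bonds along the chain from an aromatic nitrogen. For the measured compounds named here, no measured step covers this particular exchange; the steps that bear on it only show that exchanging bromo for either ring amine carries the number from the value of compound 1 to the limit. The expectation for compound 4 is therefore a step that the limit leaves unreadable from compound 3 to compound 4 in this assay, that is, none beyond the scatter, with the most likely outcome being a limit again. The estimate for compound 4 in this assay is 150 ug/mL, expected to lie between 60 ug/mL and 400 ug/mL.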

Compound 4, half-maximal inhibitory concentration: > 100 ug/mL
Compound 4: no number, only a limit; the forecaster's own chance of this, stated with the estimate: 75%; the middle value is on the limit's open side.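

In this assay compound 4 gives > 100 ug/mL, which is a limit and not a number. Placing (pyrrolidin-1-yl)methyl instead of bromo on a saturated chain carbon, three bonds along the chain from an aromatic nitrogen, gives an at least 1.8-fold higher number from compound 1 to compound 4 (0.26 log units; that floor lies within the scatter), so this exchange also shows no step beyond the scatter, and the steps among compound 2, compound 3 and compound 4 cannot be read. What compound 4 adds is that a ring amine carried on (pyrrolidin-1-yl)methyl rather than directly as pyrrolidin-1-yl also ends at the limit, the third compound to do so: the limit of > 100 ug/mL in this assay, at which 3 of the 4 values shown sit.

Going by these compounds, how far compound 2, compound 3 and compound 4 lie past that limit stays open, so the exchange of pyrrolidin-1-yl for (pyrrolidin-1-yl)methyl has no size. Also open, on these data alone, is whether a morpholine, an open-chain amine such as diethylamino, or a carboxylic acid at this place would return a number of its own, as bromo does in compound 1.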